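The source may hold more compounds than are shown below. What is called first, only, known or untested is meant among the compounds shown, and "the series" means these compounds.

Working notes on the step to compound 4. In a functional assay on SGC-7901 cells (Homo sapiens) for antiproliferative activity, read by MTT assay, with a stated time of 72 h (on this read-out higher numbers stand for weaker inhibition and lower numbers for stronger inhibition), compound 3 (`COc1ccc(-c2ccsc2-c2cc(OC)c(OC)c(OC)c2)cc1`) gives 2740 nM as the lowest of the three numbers, and its gaps to the other two lie beyond the scatter. Compound 4 (`COc1ccc(-c2ccsc2-c2cc(OC)c(OC)c(OC)c2)cc1[N+](=O)[O-]`) has nitro in place of hydrogen on an aromatic carbon, ortho to a methoxy group (nitro in place of hydrogen on an aromatic carbon). For the measured compounds named here, no measured step isolates this change. Going by the values given here, the only measured step (a 1.1-fold higher number from compound 1 to compound 2 (0.05 log units; within the scatter)) is hydrogen in place of ethyl on an oxygen next to a carbonyl group, and it lies within the scatter. Compound 1 (`CCOC(=O)c1cc(-c2ccc(OC)c([N+](=O)[O-])c2)c(-c2cc(OC)c(OC)c(OC)c2)s1`) at 19400 nM and compound 2 (`COc1ccc(-c2cc(C(=O)O)sc2-c2cc(OC)c(OC)c(OC)c2)cc1[N+](=O)[O-]`) at 21600 nM both carry the nitro, but also an ester or acid group absent from compound 3, so their numbers mix two changes. A higher number beyond the scatter is therefore expected, probably short of those two values, and the expected step is a 2.6-fold higher number from compound 3 to compound 4 (0.41 log units; beyond the scatter) in this assay on this reasoning. Compound 4 is estimated at 7000 nM with an expected range from 2000 nM to 22000 nM in this series.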

Compound 4, half-maximal inhibitory concentration: 10300 nM
Estimate against measurement, compound 4: 1.5-fold (0.17 log units) below; the measured number falls inside the stated range.
By their numbers in this assay, from the lowest: compound 3; then compounds 4, 1 and 2 (each within the scatter of the next, the first and the last beyond it).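

Nitro in place of hydrogen on an aromatic carbon, ortho to a methoxy group, can now be read alone on the shared core: this assay gives a 3.8-fold higher number from compound 3 to compound 4 (0.58 log units; beyond the scatter) as a modest step. With the nitro kept, hydrogen in place of carboxy gives a 2.1-fold lower number from compound 2 to compound 4 (0.32 log units; beyond the scatter) and is also modest, which shows that the carboxy step can be read apart from the nitro step. Hydrogen in place of ethoxycarbonyl gives a 1.9-fold lower number from compound 1 to compound 4 (0.27 log units; within the scatter) and stays within the scatter, so that change shows no clear difference in this series.

From the compounds shown here alone, whether an amine or a hydroxyl on this same aromatic carbon would stay closer to compound 3 remains open. Nothing measured here gives a reason for the nitro step.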